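Piperazin-1-yl at the cyano-flanked carbon: compound 3 to compound 4

The compounds below may be only part of what the source reports. "The series", "measured", "known", "first", "only" and "open" are said of these compounds alone.

Values in a functional assay on KB cells (Homo sapiens) for cytotoxicity, read by MTT assay, with a stated time of 3 days (a lower number here means a stronger inhibitor, a higher number a weaker inhibitor), follow
Compound 1 `N#Cc1c(O)nc(SCc2nc3ccccc3[nH]2)nc1-c1ccccc1` gives 6.2 nM
Compound 2 `N#Cc1c(NN)nc(SCc2nc3ccccc3[nH]2)nc1-c1ccccc1` gives 2.55 nM
Compound 3 `N#Cc1c(Nc2ccccn2)nc(SCc2nc3ccccc3[nH]2)nc1-c1ccccc1` gives 7.35 nM

The standing of the last entry is set by a 1.2-fold higher number from compound 1 to compound 3 (0.07 log units; within the scatter) and by a 2.9-fold higher number from compound 2 to compound 3 (0.46 log units; beyond the scatter) in this short series. Compound 4 `N#Cc1c(-c2ccccc2)nc(SCc2nc3ccccc3[nH]2)nc1N1CCNCC1` carries piperazin-1-yl in place of (pyridin-2-yl)amino on an aromatic carbon on an aromatic carbon ortho to a cyano group. All measured changes fall on that same carbon, and the third, a 2.4-fold lower number from compound 1 to compound 2 (0.39 log units; beyond the scatter) as well, is modest at most. Among the compounds with values here, no measured compound carries piperazin-1-yl. A step beyond the scatter in this assay is therefore not expected. The expected change is a 1.5-fold lower number from compound 3 to compound 4 (0.17 log units; within the scatter) and no larger. Compound 4 is estimated at 5 nM within a range of 2 nM to 12 nM on this reading.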

Compound 4, half-maximal inhibitory concentration: 2.87 nM
Beside the measured number, compound 4's estimate is 1.7-fold (0.24 log units) above it, within the range that was stated.
By their numbers in this assay, from the lowest: compounds 2 and 4 (each within the scatter of the next); then compounds 1 and 3 (each within the scatter of the next).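

At the carbon ortho to a cyano group, the ring type matters in this assay: both compound 3 and compound 4 carry a six-membered ring there, yet the non-aromatic piperazin-1-yl gives a 2.6-fold lower number from compound 3 to compound 4 (0.41 log units; beyond the scatter). It also gives a 2.2-fold lower number from compound 1 to compound 4 (0.33 log units; beyond the scatter), while a 1.1-fold higher number from compound 2 to compound 4 (0.05 log units; within the scatter) places it level with aminoamino, so a ring at this carbon can match that much smaller group. No supporting data on hand account for these steps. Open, as far as these compounds go, is whether morpholin-4-yl, with a ring oxygen replacing the ring amine, holds this level. From the compounds shown here alone, whether 4-methylpiperazin-1-yl does is equally open.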